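Chloro for methyl on the aryl ring: working notes

The source may report more compounds than this note shows. Statements on the series, on what has been measured and on what is new or still open speak of the compounds shown alone.

In an assay on isolated protein for inhibition of Thymidylate synthase (Homo sapiens) (a lower number here means a stronger inhibitor, a higher number a weaker inhibitor), the measured compounds give:
- compound 1, `Cc1ccc(-c2csc(=N)n2CC(=O)N2CCN(c3ccccc3)CC2)cc1`: 5600 nM
- compound 2, `Cc1ccc(-c2csc(=N)n2CC(=O)N2CCOCC2)cc1`: 4060 nM
- compound 3, `N=c1scc(-c2ccc(Cl)cc2)n1CC(=O)N1CCN(c2ccccc2)CC1`: 5090 nM

All three numbers lie within the scatter of one another, so no ranking among them is claimed. Compound 1 and compound 3 differ by one change, (chloro in place of methyl on an aromatic carbon), and the step of a 1.1-fold lower number from compound 1 to compound 3 (0.04 log units; within the scatter) is flat. Compound 2 and compound 1 share a core but differ in a larger part of the molecule; the difference between the two cores is not broken down here.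

Compound 4, `N=c1scc(-c2ccc(Cl)cc2)n1CC(=O)N1CCOCC1`, is not yet measured. It stands to compound 2 as compound 3 stands to compound 1: the change is chloro in place of methyl on an aromatic carbon, the same change at the same kind of place. For the measured compounds named here, with only one measured instance of this change, the expectation rests on it: the step of a 1.1-fold lower number from compound 2 to compound 4 (0.04 log units; within the scatter) is expected to be as small as the earlier one, because a 1.1-fold lower number from compound 1 to compound 3 (0.04 log units; within the scatter) was within the scatter. Compound 4 is therefore expected to give about 3700 nM in this assay, with a plausible range from 2000 nM to 7000 nM.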

Compound 4, inhibition constant: 3730 nM
For compound 4 the middle estimate is 1.0-fold (0.00 log units) below the measured one; the range from low to high includes it.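

In this assay the new step is a 1.1-fold lower number from compound 2 to compound 4 (0.04 log units; within the scatter) and it reads like the earlier one, so the change from 4-methylphenyl to 4-chlorophenyl looks the same on both cores: the same change on two cores in this assay, a 1.1-fold lower number (0.04 log units; within the scatter) from compound 1 to compound 3 and a 1.1-fold lower number (0.04 log units; within the scatter) from compound 2 to compound 4, 1.0-fold (0.00 log units) apart, within the scatter of two such steps. In these two pairs, the value of the methyl compound was therefore a fair guide to the value of its chloro partner, whichever of the two amides the compound carries. For the compounds shown here, this does not show that a change with a real effect would carry over, since both steps are flat and there are only two pairs, and it says nothing about any other core.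

Open, as far as these compounds go, is whether other groups at this place on the aryl ring, such as a methoxy group, a nitrile or a carboxylic acid, would also leave the number flat. Also open, from the compounds shown here alone, is whether the amide part can move the number at all, for instance with a basic amine or a longer chain in place of the morpholine or phenylpiperazine.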